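A few compounds are considered here, and "the series" means these few. Any claim that something is new, unique, unknown or untested is made for them only; others in the source may bear on it.

Measured compounds:
compound 1, `O=C(N/N=C/c1ccccc1)Nc1ccc(Oc2ccnc3[nH]ccc23)c(F)c1`, 640 nM
compound 2, `O=C(N/N=C/c1cccc([N+](=O)[O-])c1)Nc1ccc(Oc2ccnc3[nH]ccc23)c(F)c1`, 5180 nM

Both compounds were tested in a functional assay on HepG2 cells (Homo sapiens) for antiproliferative activity, read by MTT assay, with a stated time of 72 h; a higher number here means a weaker inhibitor, a lower number a stronger inhibitor. Of the two numbers, compound 1 has the lower one, and the gap from compound 1 to compound 2 is an 8.1-fold higher number from compound 1 to compound 2 (0.91 log units; beyond the scatter). Among the measured compounds shown here, the only change across that step is a nitro in place of hydrogen on an aromatic carbon, so the single measured step shows that adding a group to that aromatic ring weakened inhibition.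

Compound 3, `O=C(N/N=C/c1ccc(O)cc1O)Nc1ccc(Oc2ccnc3[nH]ccc23)c(F)c1`, has not yet been measured. Compared with compound 1 it differs in one place: 2,4-dihydroxyphenyl in place of phenyl on a carbon with a double bond to nitrogen. For the measured compounds named here, no measured step involves hydroxyl groups, so the nitro step is only a loose guide; it suggests that decorating this ring can cost potency, but the size and direction with hydroxyls remain open. Compound 3 is therefore expected to land near compound 1 or somewhat weaker, a step of a 1.4-fold higher number from compound 1 to compound 3 (0.15 log units; within the scatter). The estimate for compound 3 is 900 nM, with a range from 250 nM to 3500 nM.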

Compound 3, half-maximal inhibitory concentration: 4550 nM
Compound 3: the middle estimate sits 5.1-fold (0.70 log units) below what was measured, and the stated range ends below it.
By their numbers in this assay, from the lowest: compound 1; then compounds 3 and 2 (each within the scatter of the next).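

In this assay, putting 2,4-dihydroxyphenyl in place of phenyl on this carbon gives a 7.1-fold higher number from compound 1 to compound 3 (0.85 log units; beyond the scatter) and so shows that the loss of inhibition seen with the nitro group is not confined to that one group. Swapping 3-nitrophenyl for 2,4-dihydroxyphenyl gives a 1.1-fold lower number from compound 2 to compound 3 (0.06 log units; within the scatter) and leaves the two substituted rings indistinguishable here, so among these three compounds the plain phenyl ring of compound 1 is the only one that stands apart, and no compound goes against this. Nothing at hand gives a reason for the loss with either substituted ring.

Still open, going by these compounds, is whether any substituent on this ring can match compound 1, for example a single fluorine, a methyl or an amine. On these data alone, it is also open whether one hydroxyl alone would weaken inhibition as much as the pair does in compound 3.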